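The compounds below may be only part of what the source reports. "The series", "measured", "known", "first", "only" and "open" are said of these compounds alone.

Working notes on the series, following the step to compound 3. Compound 2 `Cc1ncnc2c1c(-c1cc3ccccc3o1)cn2[C@@H]1O[C@H](CO)[C@@H](O)[C@H]1O` gives > 20000 nM in a functional assay on HCT-116 cells (Homo sapiens), read by MTT assay, with a stated time of 72 h (on this read-out lower numbers stand for stronger inhibition and higher numbers for weaker inhibition), and this value is a limit of the assay, not a number. Compound 2 therefore has no measured potency to start from, and the step can only be judged against that limit.

Compound 3 `C#Cc1cn([C@@H]2O[C@H](CO)[C@@H](O)[C@H]2O)c2ncnc(C)c12` has ethynyl in place of 1-benzofuran-2-yl on an aromatic carbon.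

Going by the values given here, no measured pair isolates this change, so any expected step is indirect. Among the compounds with values here, the only guide is compound 1 `C#Cc1cn([C@@H]2O[C@H](CO)[C@@H](O)[C@H]2O)c2ncnc(SC)c12`, which also carries ethynyl on that aromatic carbon and gives 90 nM in this assay. Compound 1 is not an exact match for compound 3, so its value is only an approximate guide.

A large step towards stronger inhibition, well beyond the usual scatter, is expected in this assay. The expected change is estimated as an at least 100-fold lower number from compound 2 to compound 3 (2.00 log units; beyond the scatter). Compound 3 is estimated at 200 nM, with an expected range from 30 nM to 2000 nM.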

Compound 3, half-maximal inhibitory concentration: > 20000 nM
Compound 3 gave a limit, no number (the forecaster's own chance of this, stated with the estimate: 5%); middle value at least 100-fold (2.00 log units) from the limit.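

In this assay, ethynyl on the five-membered aromatic ring is not enough on its own to keep a measurable value: methyl in place of methylsulfanyl on an aromatic carbon, with ethynyl held fixed, gives an at least 220-fold higher number from compound 1 to compound 3 (2.34 log units; beyond the scatter). Compound 3 gives > 20000 nM in this assay, which is a limit of the assay and not a number. The step between compound 2 and compound 3 cannot be read, so the exchange of 1-benzofuran-2-yl for ethynyl remains without a size, because both values are limits: the limit of > 20000 nM in this assay, at which 2 of the 3 values shown sit.

Open, from the compounds shown here alone, is whether the value of compound 1 depends on methylsulfanyl specifically, or whether an amine or a longer chain such as ethylsulfanyl on that aromatic carbon would also give a measurable value with ethynyl held fixed. Also open, going by these compounds, is how 1-benzofuran-2-yl would read in this assay on a core that carries methylsulfanyl in place of methyl.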